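This account rests on a few compounds, and the source may have more. Where it says the series, first, only, none or still open, it means among the compounds named here.

Measured so far:
compound 1, `CON(Cc1cccs1)C(=O)COc1ccc(C)cc1`: 10 nM
compound 2, `Cc1ccc2oc(C(=O)N(Cc3cccs3)c3ccn[nH]3)cc2c1`: 40 nM

In an assay on HEK293 cells for agonist activity at transient receptor potential cation channel subfamily M member 8 (Homo sapiens), read by fluorescence and calcium flux, with a stated time of 15 min (a higher number here means that more compound is needed for the effect, a lower number that less compound is needed), compound 1 gives 10 nM and stands lowest of the two numbers; compound 2 gives 40 nM, a gap beyond the scatter. Compound 3, `Cc1ccc(OCC(=O)N(C)Cc2cccs2)cc1`, has not been measured. It differs from compound 1 by a single exchange: methyl in place of methoxy on an amide-type nitrogen. Within the data shown here, no comparable step between measured compounds is available, so the size of this step is uncertain; a modest loss in this assay is expected, though an unchanged value would not surprise. Compound 3 is estimated at 30 nM, with a range from 8 nM to 120 nM, a step of a 3.0-fold higher number from compound 1 to compound 3 (0.48 log units; beyond the scatter).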

Compound 3, half-maximal effective concentration: 400 nM
For compound 3 the middle estimate is 13-fold (1.12 log units) below the measured one, and the stated range ends below it.
By their numbers in this assay, from the lowest: compound 1; then compound 2; then compound 3.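

In this assay, methyl in place of methoxy on the amide-type nitrogen gives a 40-fold higher number from compound 1 to compound 3 (1.60 log units; beyond the scatter), a large step. This single exchange shows that this position strongly affects the number, and that methoxy there cannot be traded for methyl without much more compound being needed for the effect. No measurement at hand explains the size of this step. The compounds shown leave open whether ethoxy, hydroxy or a plain amide hydrogen on this nitrogen would give a number nearer that of compound 1 or that of compound 3.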